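The compounds below may be only part of what the source reports. "The series", "measured", "known", "first", "only" and "open" are said of these compounds alone.

Measured so far in a functional assay on NCI-H1975 cells (Homo sapiens) for cytotoxicity, read by CCK-8 assay, with a stated time of 72 h; on this read-out lower numbers stand for stronger inhibition and higher numbers for weaker inhibition:
- compound 1 `COc1ccccc1/C=c1\c(=O)[nH]/c(=C/c2cccc(Cl)c2Cl)c(=O)n1C`: 300 nM
- compound 2 `C=CCn1c(=O)/c(=C\c2ccc(Cl)c(Cl)c2)[nH]c(=O)/c1=C\c1ccccc1`: "not active" (no number reported)
- compound 3 `C=CCn1c(=O)/c(=C\c2cccc(F)c2)[nH]c(=O)/c1=C\c1ccccc1OC`: 25600 nM

Compound 3 gives the highest of the two numbers in this assay; compound 1 sits well lower, beyond the scatter, and compound 2 is reported without a number. The common core carries two arylidene groups, and the compounds differ in which aryl groups sit on them and in the group on the ring nitrogen, so no single-point comparison between measured compounds is available.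

Compound 4 `C=CCn1c(=O)/c(=C\c2ccccc2OC)[nH]c(=O)/c1=C\c1ccccc1OC` differs from compound 3 in one place: 2-methoxyphenyl in place of 3-fluorophenyl on a double-bonded chain carbon bound to an aromatic carbon. Compound 4 therefore carries the same 2-methoxyphenyl on both double-bonded chain carbons. For the measured compounds named here, no measured pair isolates this change, so the expectation rests only on the spread of the values seen.

For compound 4 the step of a 1.7-fold lower number from compound 3 to compound 4 (0.23 log units; within the scatter) is expected to be modest and not clearly beyond the scatter, with the direction uncertain. Compound 4 is estimated at 15000 nM, in the range 3000 nM to 60000 nM.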

Compound 4, half-maximal inhibitory concentration: 21500 nM
Estimate against measurement, compound 4: 1.4-fold (0.16 log units) below; the measured number falls inside the stated range.
By their numbers in this assay, from the lowest: compound 1; then compounds 4 and 3 (each within the scatter of the next).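

In this assay, for the compounds shown here, a 1.2-fold lower number from compound 3 to compound 4 (0.08 log units; within the scatter) provides the first comparison that isolates a single place. On a double-bonded chain carbon bound to an aromatic carbon, 2-methoxyphenyl and 3-fluorophenyl cannot be told apart, even though 2-methoxyphenyl counts 1 hydrogen-bond acceptor and 3-fluorophenyl 0. No supporting data bear on this result.

As far as these compounds go, compound 1 differs from compound 3 and compound 4 in more than one place, so which of its differences separates its number from theirs stays open. Also open, from the compounds shown here alone, is whether an aryl group carrying an amine or a carboxylic acid at this place would give a step beyond the scatter, and whether a longer chain on the ring nitrogen would alter the reading of this change.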